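The source may hold more compounds than are shown below. What is called first, only, known or untested is meant among the compounds shown, and "the series" means these compounds.

In an ADME assay on HaCaT cells (Homo sapiens) for antiproliferative activity, with a stated time of 48 h (a lower number here means a stronger inhibitor, a higher number a weaker inhibitor), the methyl ester compound 1 `CCN(CC)c1ccc(-c2ccc(C(=O)OC)cc2)nn1` gives 80 nM. The carboxylic acid compound 2 `CCN(CC)c1ccc(-c2ccc(C(=O)O)cc2)nn1` is reported as > 25000 nM, which is a limit of the assay and not a number. The ethyl ester compound 3 `CCOC(=O)c1ccc(-c2ccc(N(CC)CC)nn2)cc1` gives 500 nM, the higher of the two true numbers, with compound 1 its nearest neighbour. Compound 4 `CCOC(=O)c1ccc(-c2ccc(OCC)nn2)cc1` keeps that ethyl ester but carries ethoxy in place of diethylamino on an aromatic carbon. Among the measured compounds shown here, no measured step touches this position, since all of them lie at the ester, so they bear on it only through their size. The ester changes gave a 6.3-fold higher number from compound 1 to compound 3 (0.80 log units; beyond the scatter), a modest step, as well as an at least 310-fold higher number from compound 1 to compound 2 (2.49 log units; beyond the scatter) and an at least 50-fold lower number from compound 2 to compound 3 (1.69 log units; beyond the scatter), both large. These steps show that this assay responds strongly to single changes, and the swap at this new position is expected to cost some activity, though with little certainty. The expected change is a 3.0-fold higher number from compound 3 to compound 4 (0.48 log units; beyond the scatter). The estimated value for compound 4 is 1500 nM, within an expected range of 250 nM to 10000 nM.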

Compound 4, half-maximal inhibitory concentration: > 25000 nM
Compound 4 ended at the assay's limit; the forecaster's own chance of this, stated with the estimate: 15%; middle value at least 16-fold (1.22 log units) from the limit.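

In this assay, ethoxy in place of diethylamino on an aromatic carbon, with the ethyl ester kept, gives an at least 50-fold higher number from compound 3 to compound 4 (1.69 log units; beyond the scatter), so a single change away from the ester can also produce a large step. The two groups have equal counts of hydrogen-bond donors and acceptors and neither carries a net charge, but they differ in heavy atoms and in oxygen against nitrogen, so an ester alone does not secure activity in this pair. The reading for compound 4 is a limit of the assay and not a number: the limit of > 25000 nM in this assay, at which 2 of the 4 values shown sit.

The compounds shown leave open whether the step follows from the oxygen or from the smaller group. They also leave open how a dimethylamino group or a longer alkoxy chain at this position would behave, with either the methyl ester or the ethyl ester.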